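Series notes: ring exchange on the carbonyl carbon

The source may hold more compounds than are shown below. What is called first, only, known or untested is meant among the compounds shown, and "the series" means these compounds.

Measured compounds:
compound 1 `C#CCOc1ccc(/C=C/C(=O)c2cccc(OC)c2)cc1OC`, 13800 nM
compound 2 `C#CCOc1ccc(/C=C/C(=O)c2ccc(OC)c(OC)c2)cc1OC`, 13600 nM

In a functional assay on MDA-MB-231 cells (Homo sapiens) for cytotoxicity, with a stated time of 72 h (a lower number here means a stronger inhibitor, a higher number a weaker inhibitor), compound 1 gives 13800 nM and compound 2 gives 13600 nM; the step of a 1.0-fold lower number from compound 1 to compound 2 (0.01 log units; within the scatter) is within the scatter, so neither compound can be placed above the other. Compound 3 `C#CCOc1ccc(/C=C/C(=O)c2ccccc2C)cc1OC` differs from compound 1 by 2-methylphenyl in place of 3-methoxyphenyl on a carbonyl carbon. Going by the values given here, only the step from compound 1 to compound 2 touches this ring, and it showed nothing beyond the scatter; no measured step exchanges the ring itself. For compound 3 the expected step is therefore a 1.0-fold higher number from compound 1 to compound 3 (0.01 log units; within the scatter), none beyond the scatter. The estimate for compound 3 is 14000 nM, between 5000 nM and 40000 nM.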

Compound 3, half-maximal inhibitory concentration: 14800 nM
Estimate against measurement, compound 3: 1.1-fold (0.02 log units) below; measured number inside the range.
By their numbers in this assay, from the lowest: compounds 2, 1 and 3 (each within the scatter of the next).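

In this assay the step now covers exchange of the whole ring on the carbonyl carbon, not just addition of a methoxy group: 2-methylphenyl in place of 3-methoxyphenyl gives a 1.1-fold higher number from compound 1 to compound 3 (0.03 log units; within the scatter). The entering group has no hydrogen-bond acceptor where the leaving group has one, and the number still stays within the scatter. No measured evidence bears on this result.

Still open, on these data alone, is whether a ring carrying an amine or a carboxylic acid on this carbonyl carbon would move the number beyond the scatter.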